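Trading a Phenyl for a Methyl in a Cytotoxicity Series

The compounds below may be only part of what the source reports. "The series", "measured", "known", "first", "only" and "open" are said of these compounds alone.

Measured compounds:
- compound 1, `COc1cc(-c2cc(COCc3cn(Cc4cc(-c5ccccc5)cnc4Cl)nn3)on2)cc(OC)c1OC`, 43100 nM
- compound 2, `COc1cc(C2=NOC(COCc3cn(Cc4cc(-c5ccc(C)cc5)cnc4Cl)nn3)C2)cc(OC)c1OC`, 9700 nM

In a functional assay on HeLa cells (Homo sapiens) for cytotoxicity, read by MTT assay, with a stated time of 48 h (on this read-out lower numbers stand for stronger inhibition and higher numbers for weaker inhibition), compound 1 gives 43100 nM, the highest of the two numbers recorded. Compound 2 differs from compound 1 in several places. In this assay compound 2 gives 9700 nM; the gap between the two values lies beyond the scatter, and nothing more can be drawn from the pair.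

The unmeasured compound 3, `COc1cc(-c2cc(COCc3cn(Cc4cc(C)cnc4Cl)nn3)on2)cc(OC)c1OC`, departs from compound 1 by a single exchange: methyl in place of phenyl on an aromatic carbon. Because compound 1 stands at 43100 nM and no comparable single change has been measured, the direction of the step cannot be anchored. A modest step is expected, most likely toward a weaker value or none beyond the scatter, giving a 1.3-fold higher number from compound 1 to compound 3 (0.11 log units; within the scatter). Compound 3 is therefore estimated at 55000 nM, with a range from 15000 nM to 180000 nM.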

Compound 3, half-maximal inhibitory concentration: 57700 nM
Compound 3: the middle estimate sits 1.0-fold (0.02 log units) below what was measured; low and high end bracket the measured number.
By their numbers in this assay, from the lowest: compound 2; then compounds 1 and 3 (each within the scatter of the next).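

Going by these compounds alone, exchanging phenyl for methyl on this aromatic carbon, para to the chloro group, gives the first single change that can be read in this assay, namely a 1.3-fold higher number from compound 1 to compound 3 (0.13 log units; within the scatter), which is within the scatter. At this position, then, the six-membered aromatic ring of carbon can give way to methyl without a change in the read-out that stands beyond the scatter, so the phenyl of compound 1 shows no measurable contribution here. Nothing at hand explains this outcome.

Going by these compounds, whether an amine, a carboxylic acid or a longer chain on this carbon would move the number beyond the scatter remains open. Compound 2 differs from these compounds in several places, so its lower value cannot be assigned to any one of them.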